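The source may report more compounds than this note shows. Statements on the series, on what has been measured and on what is new or still open speak of the compounds shown alone.

Among the measured compounds shown here, compound 1 `CC(=O)Nc1ccc2c(=O)n(O)c(=O)[nH]c2c1` is the only compound with a result: in an assay on isolated protein for inhibition of deoxyribonuclease-1 (Homo sapiens) (a lower number here means a stronger inhibitor, a higher number a weaker inhibitor), compound 1 gives > 100000 nM, which is a limit of the assay rather than a number, as the limit of > 100000 nM in this assay, at which 1 of the 2 values shown sits, notes. Compound 2 `O=C(c1nc(-c2cccs2)[nH]c(=O)c1O)N1CCCC1` has in this assay only the entry "not determined" (no result reported), so compound 2 stands on no number at all. Compound 3 `O=C(Nc1cccnc1)c1nc(-c2cccs2)[nH]c(=O)c1O` differs from compound 2 in one place: (pyridin-3-yl)amino in place of pyrrolidin-1-yl on a carbonyl carbon. For the measured compounds named here, with no measured step to lean on, no direction or size of change in this assay can be expected beyond the usual scatter. Compound 3 is estimated at 10000 nM, with a range from 500 nM to 100000 nM.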

Compound 3, half-maximal inhibitory concentration: > 100000 nM
Compound 3 was reported as a limit; the forecaster's own chance of this, stated with the estimate: 40%; middle value at least 10-fold (1.00 log units) away from the limit.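

No step can be read between compound 2, which stands on no number, and compound 3. In this assay compound 3 gives > 100000 nM, a limit of the assay and not a number. The compounds shown leave open which structural change, if any, would give a measured number.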